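Removing One Methoxy Group: An Expected Step in Growth Inhibition

The source may report more compounds than this note shows. Statements on the series, on what has been measured and on what is new or still open speak of the compounds shown alone.

Of the compounds shown here, three built on one shared core have been tested in a functional assay on SW-620 cells (Homo sapiens) for inhibition, read by sulforhodamine B assay, with a stated time of 48 h; a lower number here means a stronger inhibitor of growth, a higher number a weaker inhibitor of growth. Compound 1 `Nc1cc(N)c2nc(-c3ccccc3)c(NCc3ccc(Cl)c(Cl)c3)nc2c1` carries a benzyl amine bearing two chlorine atoms, and in this assay compound 1 gives 3240 nM. Compound 2 `COc1cc(CNc2nc3cc(N)cc(N)c3nc2-c2ccccc2)cc(OC)c1OC` instead carries a benzyl amine bearing three methoxy groups, and in this assay compound 2 gives 1550 nM. Compound 3 `Nc1cc(N)c2nc(-c3ccccc3)c(Sc3ccc(Cl)c(Cl)c3)nc2c1`, in which a sulfur atom joins a phenyl ring with two chlorine atoms directly to the core, gives 20900 nM in this assay. Compound 2 therefore stands at the lowest number of the three, separated from both compound 1 and compound 3 by more than the usual scatter.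

Compound 4 `COc1ccc(CNc2nc3cc(N)cc(N)c3nc2-c2ccccc2)cc1OC` has not yet been measured. It differs from compound 2 in a single place: hydrogen in place of methoxy on an aromatic carbon. Going by the values given here, no two measured compounds differ from each other in only one place, so no measured step tells directly what such a change does here. The change is a small one and the rest of compound 2 is kept, so the estimated step of a 1.4-fold higher number from compound 2 to compound 4 (0.15 log units; within the scatter) is expected to be modest, leaning toward a somewhat weaker inhibitor, and it may well fall within the scatter. In this assay compound 4 is expected to give about 2200 nM, in a range from 900 nM to 5500 nM.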

Compound 4, concentration for 50% growth inhibition: 5250 nM
The estimate for compound 4 lay 2.4-fold (0.38 log units) below the measured number; low and high end bracket the measured number.
By their numbers in this assay, from the lowest: compound 2; then compounds 1 and 4 (each within the scatter of the next); then compound 3.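

Hydrogen in place of this one methoxy group, on an aromatic carbon ortho to a methoxy group, gives a 3.4-fold higher number from compound 2 to compound 4 (0.53 log units; beyond the scatter) in this assay, the first measured change at a single place on the ring of compound 2. This methoxy group therefore matters at this position, even though it is only a small part of the molecule. By contrast, 3,4-dimethoxyphenyl in place of 3,4-dichlorophenyl gives a 1.6-fold higher number from compound 1 to compound 4 (0.21 log units; within the scatter), so in this assay compound 4 cannot be told apart from compound 1, even though two groups on the ring differ between them.

Nothing measured on these compounds explains why removing the methoxy group produces a step of this size. From the compounds shown here alone, it remains open whether this position responds to the methoxy group in particular or would respond similarly to another group, such as a hydroxyl group, a fluorine atom or an amine, and whether removing either of the other two methoxy groups of compound 2 would produce a similar step.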